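The compounds below may be only part of what the source reports. "The series", "measured", "known", "first", "only" and "open" are said of these compounds alone.

Working notes on the series. The shared core of compound 1 `CCOC(=O)C1=C(C)NC(=S)NC1c1ccc(O)c(O)c1` carries two hydroxy groups on the aromatic ring; in a functional assay on NCI-H460 cells (Homo sapiens) for inhibition, read by sulforhodamine B assay, with a stated time of 48 h (on this read-out lower numbers stand for stronger inhibition of growth and higher numbers for weaker inhibition of growth), compound 1 gives 31.7 ug/mL, the lowest of the three numbers, though within the scatter of both companions. Among the measured compounds shown here, compound 2 `CCOC(=O)C1=C(C)NC(=O)NC1c1ccc(O)c(O)c1` gives 34 ug/mL and compound 3 `CCOC(=O)C1=C(C)NC(=O)NC1c1ccc(O)cc1` gives 40.6 ug/mL; the one measured step, a 1.2-fold higher number from compound 2 to compound 3 (0.08 log units; within the scatter), shows that removing one hydroxy leaves the read-out essentially unchanged. Compound 4 `CCOC(=O)C1=C(C)NC(=S)NC1c1ccc(O)c(OC)c1` differs from compound 1 by methyl in place of hydrogen on an oxygen on an aromatic ring. For the measured compounds named here, the closest precedent is that hydroxy-to-hydrogen step, which stayed within the scatter, so no step beyond the scatter is expected in this assay, in either direction. Compound 4 is therefore estimated at 33 ug/mL, range 20 ug/mL to 55 ug/mL, a step of a 1.0-fold higher number from compound 1 to compound 4 (0.02 log units; within the scatter).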

Compound 4, concentration for 50% growth inhibition: 180 ug/mL
Estimate against measurement, compound 4: 5.5-fold (0.74 log units) below, outside the stated range (above it).
By their numbers in this assay, from the lowest: compounds 1, 2 and 3 (each within the scatter of the next); then compound 4.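

In this assay, among the compounds shown here, hydroxy to methoxy gives a 5.7-fold higher number from compound 1 to compound 4 (0.75 log units; beyond the scatter) as the first step beyond the scatter. The read-out therefore responds to a change on this oxygen on an aromatic ring, whereas a 1.2-fold higher number from compound 2 to compound 3 (0.08 log units; within the scatter) gave no such sign, though that step concerns a different change on a different pair. Nothing at hand gives a reason for the step.

Open, from the compounds shown here alone, is whether a longer chain on that oxygen, such as ethyl, or an amine in place of the hydroxy would give a step of similar size. Also open, going by these compounds, is whether methyl on this oxygen has the same effect on compound 2.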